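A few compounds are considered here, and "the series" means these few. Any claim that something is new, unique, unknown or untested is made for them only; others in the source may bear on it.

- compound 1 `CCCC(=O)CC/C=C/C=C/C#CC#C/C=C/COC(C)=O`: 14200 nM
- compound 2 `CCCC(=O)CC/C=C/C=C/C#CC#C/C=C/COC(=O)c1ccccc1`: 26700 nM
- compound 3 `CCCC(=O)CC/C=C/C=C/C#CC#C/C=C/COC(=O)CCl`: not yet measured

In an ADME assay on NIH3T3 cells (Mus musculus) for cytotoxicity, read by sulforhodamine B assay, with a stated time of 96 h (a higher number here means that more compound is needed for the effect, a lower number that less compound is needed), compound 2, at 26700 nM, lies within the scatter of compound 1. Compound 3 carries chloromethyl in place of phenyl on a carbonyl carbon. Among the compounds with values here, the only measured change at this carbonyl carbon, phenyl in place of methyl, gave a 1.9-fold higher number from compound 1 to compound 2 (0.27 log units; within the scatter). Chloromethyl itself is untested, so no step beyond the scatter is expected in this assay. The estimated step is a 1.8-fold lower number from compound 2 to compound 3 (0.25 log units; within the scatter). Compound 3 is expected at 15000 nM, with an estimated range of 6000 nM to 32000 nM.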

Compound 3, half-maximal effective concentration: 11900 nM
For compound 3 the middle estimate is 1.3-fold (0.10 log units) above the measured one; the range from low to high includes it.
By their numbers in this assay, from the lowest: compounds 3, 1 and 2 (each within the scatter of the next, the first and the last beyond it).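

Chloromethyl in place of phenyl on this carbonyl carbon gives a 2.2-fold lower number from compound 2 to compound 3 (0.35 log units; beyond the scatter) in this assay, the first step at this position beyond the scatter, though a modest one. Chloro in place of hydrogen on the saturated chain carbon gives a 1.2-fold lower number from compound 1 to compound 3 (0.08 log units; within the scatter), which leaves chloromethyl and methyl within the scatter of each other. Nothing measured here explains either step.

As far as these compounds go, whether an aminomethyl group or a longer saturated chain on this carbonyl carbon would widen the range stays open, as does whether bromo would behave like chloro.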